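The compounds below may be only part of what the source reports. "The series", "measured", "known", "first", "only" and "open" are said of these compounds alone.

Of the compounds shown here, three built on one shared core have been tested in a functional assay on HeLa cells (Homo sapiens) for antiproliferative activity, read by MTT assay, with a stated time of 48 h; on this read-out lower numbers stand for stronger inhibition and higher numbers for weaker inhibition. Compound 1 `CN(C)CCn1c(N)c(-c2nc3ccccc3[nH]2)c2nc(C#N)c(C#N)nc21` gives 8880 nM in this assay. Compound 2 `CN1CCN(CCCn2c(N)c(-c3nc4ccccc4[nH]3)c3nc(C#N)c(C#N)nc32)CC1` gives 15600 nM, and compound 3 `CCN(CC)CCCCn1c(N)c(-c2nc3ccccc3[nH]2)c2nc(C#N)c(C#N)nc21` gives 10100 nM. Among these three numbers compound 3 stands second highest, nearest to compound 1 and furthest from compound 2, and both of those gaps lie within the scatter. The measured steps all concern the group at the end of the chain on the core nitrogen: a 1.8-fold higher number from compound 1 to compound 2 (0.24 log units; within the scatter), a 1.1-fold higher number from compound 1 to compound 3 (0.06 log units; within the scatter) and a 1.5-fold lower number from compound 2 to compound 3 (0.19 log units; within the scatter). None of them moves this assay beyond its scatter.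

Compound 4 `N#Cc1nc2c(-c3nc4ccccc4[nH]3)c(N)n(CCCNc3ccccc3)c2nc1C#N` has not yet been measured. It differs from compound 3 by anilino in place of (diethylamino)methyl on a saturated chain carbon, three bonds along the chain from an aromatic nitrogen. The earlier steps shown here exchanged one amine for another in the same region of the chain, and none of them brought an aromatic ring to that place, so no measured step speaks directly to this change. Since each exchange at this chain end left this assay within its scatter, the number expected for compound 4 amounts to a 1.0-fold lower number from compound 3 to compound 4 (0.00 log units; within the scatter), no step beyond the scatter. The estimate for compound 4 is therefore 10000 nM, expected to lie between 4000 nM and 25000 nM.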

Compound 4, half-maximal inhibitory concentration: 26300 nM
The estimate for compound 4 lay 2.6-fold (0.42 log units) below the measured number; the whole stated range lies below it.
By their numbers in this assay, from the lowest: compounds 1, 3, 2 and 4 (each within the scatter of the next, the first and the last beyond it).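

In this assay this chain end shows its first steps beyond the scatter, though both are modest: anilino in place of (diethylamino)methyl, three bonds along the chain from an aromatic nitrogen, gives a 2.6-fold higher number from compound 3 to compound 4 (0.42 log units; beyond the scatter), and anilinomethyl in place of dimethylamino, two bonds along the chain, gives a 3.0-fold higher number from compound 1 to compound 4 (0.47 log units; beyond the scatter). The exchanges among amines had not shown that this place can respond at all, yet anilino is not set apart from every amine, since anilino in place of 4-methylpiperazin-1-yl gives a 1.7-fold higher number from compound 2 to compound 4 (0.23 log units; within the scatter), which stays within the scatter. No measurement on these compounds accounts for the steps.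

Still open, from the compounds shown here alone, is whether the step belongs to the aromatic ring or to the hydrogen-bond donor that anilino brings, which a cyclohexylamino or an N-methylanilino group at the same place could separate. Also open, going by these compounds, is how a 2-anilinoethyl chain or a carboxylic acid at the chain end would read in this assay.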